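Adding a Third Methoxy Group to an Aryl Sulfonate

A few compounds are considered here, and "the series" means these few. Any claim that something is new, unique, unknown or untested is made for them only; others in the source may bear on it.

Compound 1 `COc1ccc(OS(=O)(=O)c2ccc(N3CCN(C)C3=O)cc2)cc1OC` and compound 2 `COc1ccc(OS(=O)(=O)c2ccc(N3CCN(C)C3=O)cc2)cc1` share one core, while compound 3 `CCCN1CCN(c2ccc(S(=O)(=O)Oc3cc(OC)cc(OC)c3)cc2)C1=O` is built on a different core; the difference between the two cores is not broken down here. In a functional assay on M21 cells (Homo sapiens) for antiproliferative activity, read by sulforhodamine B assay, with a stated time of 48 h (a lower number here means a stronger inhibitor, a higher number a weaker inhibitor), compound 1 gives 8500 nM. Compound 2 reaches only a limit of this assay, > 100000 nM. Compound 3 gives 33000 nM in this assay. The change methoxy in place of hydrogen on an aromatic carbon produced an at least 11-fold lower number from compound 2 to compound 1 (1.07 log units; beyond the scatter), a step read against (the limit of > 100000 nM in this assay, at which 1 of the 3 values shown sits). The same kind of change, (methoxy in place of hydrogen on an aromatic carbon), leads from compound 3 to compound 4 `CCCN1CCN(c2ccc(S(=O)(=O)Oc3cc(OC)c(OC)c(OC)c3)cc2)C1=O`; here the new group sits ortho to two methoxy groups and para to a large group, whereas before it sat ortho to a methoxy group and meta to a large group. That earlier step an at least 11-fold lower number from compound 2 to compound 1 (1.07 log units; beyond the scatter) is the basis for the expectation that follows. Compound 4 is expected to show a 13-fold lower number from compound 3 to compound 4 (1.12 log units; beyond the scatter) in this assay. The estimated value for compound 4 is 2500 nM.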

Compound 4, half-maximal inhibitory concentration: 3900 nM
Compound 4: the middle estimate sits 1.6-fold (0.19 log units) below what was measured, within the range that was stated.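

In this assay, methoxy in place of hydrogen gave an 8.5-fold lower number from compound 3 to compound 4 (0.93 log units; beyond the scatter), so the change that lowered the number on the core of compound 1 also lowered it on the core of compound 3. The two steps point the same way, but their sizes cannot be told apart: the same change on two cores in this assay, an at least 11-fold lower number (1.07 log units; beyond the scatter) from compound 2 to compound 1 and an 8.5-fold lower number (0.93 log units; beyond the scatter) from compound 3 to compound 4; the limit leaves it open whether they differ. This is one pair on each of two cores, with the new group in a different place on the ring in each pair, so it shows that the change carried over here and gives no general rule for other cores.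

The compounds shown leave open whether an ethoxy or a hydroxyl group in the same place would also lower the number. They also leave open whether the step would hold on a core carrying an amine.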